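From 3-hydroxyazepan-1-yl to 3-hydroxy-3-methylazepan-1-yl

This account rests on a few compounds, and the source may have more. Where it says the series, first, only, none or still open, it means among the compounds named here.

Compound 1 `O=C(Nc1ccc(F)c(Cl)c1)c1ccc(F)c(S(=O)(=O)N2CCSCC(O)C2)c1`: 19000 nM
Compound 2 `O=C(Nc1ccc(F)c(Cl)c1)c1ccc(F)c(S(=O)(=O)N2CCCCC(O)C2)c1`: 15000 nM

In an ADME assay on HepG2 2.2.15 cells (Homo sapiens) for cytotoxicity, read by luminescence, with a stated time of 3 days (a higher number here means that more compound is tolerated, a lower number that less compound is tolerated), compound 2 gives 15000 nM, within the scatter of compound 1 at 19000 nM. Next comes compound 3 `CC1(O)CCCCN(S(=O)(=O)c2cc(C(=O)Nc3ccc(F)c(Cl)c3)ccc2F)C1`, with methyl in place of hydrogen on a saturated ring carbon. For the measured compounds named here, the only measured step in this ring is a 1.3-fold lower number from compound 1 to compound 2 (0.10 log units; within the scatter). It exchanges a ring atom, adds no methyl and stays within the scatter. No step beyond the scatter is therefore expected in this assay. The expected change is a 1.1-fold higher number from compound 2 to compound 3 (0.03 log units; within the scatter). Compound 3 is estimated at 16000 nM, with a range from 8000 nM to 32000 nM.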

Compound 3, half-maximal cytotoxic concentration: 10000 nM
For compound 3 the middle estimate is 1.6-fold (0.20 log units) above the measured one, and the stated range covers the measured number.
By their numbers in this assay, from the lowest: compounds 3, 2 and 1 (each within the scatter of the next).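

In this assay, for the compounds shown here, methyl in place of hydrogen on this saturated ring carbon, two ring bonds from the ring nitrogen, gives a 1.5-fold lower number from compound 2 to compound 3 (0.18 log units; within the scatter) and is the first step at this position to add a carbon. The step that combines this methyl with the ring-atom exchange is a 1.9-fold lower number from compound 1 to compound 3 (0.28 log units; within the scatter), so even the two changes together leave the numbers within the scatter. Nothing available bears on a cause for these steps.

Open, from the compounds shown here alone, is how a larger or charged group on this ring carbon, such as ethyl or aminomethyl, would read in this assay and whether a methoxy group in place of the hydroxyl would do the same.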